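The compounds below may be only part of what the source reports. "The series", "measured", "known", "first", "only" and "open" are said of these compounds alone.

Going by the values given here, compound 1 `COc1ccc2[nH]c(C(=O)N3CC(=O)N(Cc4ccccc4)[C@@H](CN4CCC5(CC4)CC5)C3)cc2c1` is the only compound here with a numeric reading: in an ADME assay on Vero cells (Chlorocebus sabaeus) for cytotoxicity, with a stated time of 7 days (a higher number here means that more compound is tolerated, a lower number that less compound is tolerated), compound 1 gives 17100 nM. Compound 2 `COc1ccc2[nH]c(C(=O)N3CC(=O)N(Cc4cccc(OC)n4)[C@@H](Cc4ccccc4)C3)cc2c1` is different in that its result is a limit of the measurement rather than a number; in this assay compound 2 gives > 30000 nM. Among the compounds with values here, that limit, (the limit of > 30000 nM in this assay, at which 1 of the 2 values shown sits), is all that is known of compound 2, so no measured step between two numbers exists to lean on.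

Compound 3 `COc1ccc2[nH]c(C(=O)N3CC(=O)N(Cc4ccccc4)[C@@H](CN4CCc5ccccc5C4)C3)cc2c1` is the compound still to be tested. It differs from compound 1 in one place: a group of 10 heavy atoms (9 carbon, 1 nitrogen; one six-membered non-aromatic ring with 1 hetero atom, one six-membered aromatic ring of carbon only) in place of a group of 8 heavy atoms (7 carbon, 1 nitrogen; one three-membered non-aromatic ring of carbon only, one six-membered non-aromatic ring with 1 hetero atom), on a saturated chain carbon bound to a saturated ring carbon. Within the data shown here, with no measured step of this kind available, only a modest movement in this assay is expected, and no clear direction can be argued for it, so the step from compound 1 to compound 3 is estimated at a 1.2-fold lower number from compound 1 to compound 3 (0.09 log units; within the scatter), which would lie within the usual scatter. Compound 3 is therefore estimated to give about 14000 nM in this assay, in a range from 5000 nM to 30000 nM.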

Compound 3, half-maximal cytotoxic concentration: 51800 nM
Beside the measured number, compound 3's estimate is 3.7-fold (0.57 log units) below it; the measured number lies above the stated range.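

Putting 1,2,3,4-tetrahydroisoquinolin-2-yl in place of the group with the three-membered ring, on a saturated chain carbon bound to a saturated ring carbon, gives a 3.0-fold higher number from compound 1 to compound 3 (0.48 log units; beyond the scatter) in this assay and so means that more compound is tolerated. Compounds 1 and 2 differ in more than one place and could not show this: a change confined to this one group can move the number beyond the usual scatter. Nothing shown gives a reason for the direction of this step.

A single step cannot tell whether the higher number goes with gaining the six-membered aromatic ring or with losing the three-membered ring. It also leaves open how a plain piperidine or a morpholine at this place would compare with compound 1 and compound 3.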